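The compounds below may be only part of what the source reports. "The series", "measured", "known", "first", "only" and "open" are said of these compounds alone.

Measured compounds:
compound 1, `COc1c(NCCN)c(F)cc2c(=O)c(C(=O)O)cn(Cc3ccc(-c4ccccc4)cc3)c12`, 10%
compound 2, `CNCCNc1c(F)cc2c(=O)c(C(=O)O)cn(Cc3ccc(-c4ccccc4)cc3)c2c1OC`, 10%

In an assay on isolated protein for inhibition of DNA topoisomerase 1 (Homo sapiens), with a stated time of 15 min, tested at 200 uM (on this read-out lower numbers stand for less inhibition and higher numbers for more inhibition at the one concentration tested (going by the name of the read-out)), compound 1 gives 10% and compound 2 gives 10%. For the measured compounds named here, compound 2 stands level with compound 1 at the digits reported; the one measured step, no change at the digits printed from compound 1 to compound 2 (within the scatter), lies within the scatter. Compound 3, `CNCCCCNc1c(F)cc2c(=O)c(C(=O)O)cn(Cc3ccc(-c4ccccc4)cc3)c2c1OC`, has not yet been measured. It differs from compound 2 in one place: 2-(methylamino)ethyl in place of methylamino on a saturated chain carbon, two bonds along the chain from a nitrogen on an aromatic ring. Going by the values given here, the only measured step, methyl in place of hydrogen on an amine nitrogen, touches the same chain end but is a different kind of change, and it left the read-out where it was. Nothing measured here points to a step beyond the scatter in either direction in this assay. Compound 3 is therefore expected to give 10%, within a range of 0% to 25%. The expected step is no change at the digits printed from compound 2 to compound 3 (within the scatter), none beyond the scatter.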

Compound 3, a percentage reported as inhibition, at one concentration (the size of the read-out at that concentration, not a potency): 10%
Compound 3: middle estimate and measured number agree at the digits printed; the range from low to high includes it.
By their numbers in this assay, from the lowest: compounds 1, 2 and 3 (each within the scatter of the next).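

In this assay, 2-(methylamino)ethyl in place of methylamino on a saturated chain carbon, two bonds along the chain from a nitrogen on an aromatic ring, gives no change at the digits printed from compound 2 to compound 3 (within the scatter), so the read-out stays level with this change in chain length, as it did with the earlier methyl on the amine nitrogen. Taking 2-(methylamino)ethyl in place of amino at the same place gives no change at the digits printed from compound 1 to compound 3 (within the scatter), which shows that the larger replacement also leaves the read-out level. Nothing available offers an account of why these values stay level.

The compounds shown leave open whether a longer chain would still read the same in this assay. They also leave open whether a carboxylic acid or a hydroxyl group at the chain end would move the read-out beyond the scatter.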